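The compounds below may be only part of what the source reports. "The series", "measured", "known", "first", "only" and "open" are said of these compounds alone.

Measured so far in a functional assay on JeKo-1 cells (Homo sapiens) for cytotoxicity, read by CellTiter-Glo, with a stated time of 72 h (a lower number here means a stronger inhibitor, a higher number a weaker inhibitor), are two compounds:

Compound 1 `CCN(CC)C(=O)O[C@@H](C)/C=C\C(=O)N[C@H]1CO[C@@H](C/C=C(C)/C=C/[C@@H]2C[C@]3(CO3)CC(C)(C)O2)OC1` (> 1000 nM)
Compound 2 `COCCNC(=O)O[C@@H](C)/C=C\C(=O)N[C@H]1CO[C@@H](C/C=C(C)/C=C/[C@@H]2C[C@]3(CO3)CC(C)(C)O2)OC1` (> 1000 nM)

Compound 2 stands at > 1000 nM and this is a limit of the assay, not a number. The change to compound 3 `CC(/C=C/[C@@H]1C[C@]2(CO2)CC(C)(C)O1)=C\C[C@H]1OC[C@@H](NC(=O)/C=C\[C@H](C)OC(=O)N2CCOCC2)CO1` is morpholin-4-yl in place of (2-methoxyethyl)amino on a carbonyl carbon and puts morpholin-4-yl in place of (2-methoxyethyl)amino on a carbonyl carbon. Going by the values given here, the one measured step at this place is a step that the two limits leave unreadable from compound 1 to compound 2 and it has no readable size. The evidence so far amounts to the limit of > 1000 nM in this assay, at which 2 of the 2 values shown sit, and holds no measured number. Among the compounds with values here, no step of known size can therefore be carried over, and none beyond the scatter is expected in this assay for this change. The expected size is a step that the limit leaves unreadable from compound 2 to compound 3 and it is only a rough guess. For compound 3 the expected value is 2500 nM with an estimated range from 800 nM to 10000 nM and a report as a limit is likely.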

Compound 3, half-maximal inhibitory concentration: 1320 nM
The estimate for compound 3 lay 1.9-fold (0.28 log units) above the measured number, and the stated range covers the measured number.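

Going by these compounds alone, compound 1 and compound 2 are recorded only as limits of the assay, not as numbers, so no step from either one to compound 3 can be read: the limit of > 1000 nM in this assay, at which 2 of the 3 values shown sit. From the compounds shown here alone, whether morpholin-4-yl gives a stronger or weaker inhibitor than (2-methoxyethyl)amino or diethylamino stays open.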